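The source may hold more compounds than are shown below. What is called first, only, known or untested is meant among the compounds shown, and "the series" means these compounds.

Compound 1 `CCC1=C(O)c2c(oc(-c3cccc(C)c3)cc2=O)C(CC)(CC)C1=O` gives 3.69 uM
Compound 2 `CCC1=C(O)c2c(oc(-c3ccc(C)c(F)c3)cc2=O)C(CC)(CC)C1=O` gives 2.95 uM

Both numbers come from a functional assay on KBVIN cells (Homo sapiens) for antiproliferative activity, read by sulforhodamine B assay, with a stated time of 3 days (on this read-out lower numbers stand for an effect already at smaller amounts and higher numbers for an effect only at larger amounts of compound), and lie within the usual scatter of each other, so compound 2 stands level with compound 1. Compound 3 `CCC1=C(O)c2c(oc(-c3cc(C)c(C)cc3C)cc2=O)C(CC)(CC)C1=O` has not been measured yet. It carries 2,4,5-trimethylphenyl in place of 3-fluoro-4-methylphenyl on an aromatic carbon of the shared core, and 2,4,5-trimethylphenyl in place of 3-fluoro-4-methylphenyl on an aromatic carbon counts what that exchange means. For the measured compounds named here, only one measured step touches this same group, and no measured compound carries the 2,4,5-trimethylphenyl group, so the evidence is thin. Going by compound 2 at 2.95 uM and by the small size of a 1.3-fold lower number from compound 1 to compound 2 (0.10 log units; within the scatter) as that single step, no change beyond the scatter is expected in this assay in either direction. The expected result is a 1.0-fold higher number from compound 2 to compound 3 (0.01 log units; within the scatter) as the step. For compound 3 the estimated value is 3 uM with an expected range from 1.2 uM to 7.5 uM as its bounds.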

Compound 3, concentration for half-maximal effect: 4.37 uM
Compound 3: middle estimate off by 1.5-fold (0.16 log units), on the low side, and the stated range covers the measured number.
By their numbers in this assay, from the lowest: compounds 2, 1 and 3 (each within the scatter of the next).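

In this assay the 2,4,5-trimethylphenyl group gives a 1.5-fold higher number from compound 2 to compound 3 (0.17 log units; within the scatter) and also a 1.2-fold higher number from compound 1 to compound 3 (0.07 log units; within the scatter) when set against the 3-methylphenyl group. Three differently substituted phenyl rings have now been tried at this position on the shared core, and their numbers cannot be ranked, even though the methyl groups and the fluorine differ from one compound to the next. Nothing at hand explains why these groups read alike.

From the compounds shown here alone, all three rings carry only methyl or fluorine, so the effect of an amine, a carboxylic acid or a longer alkyl chain at this position remains open. Going by these compounds, the ethyl groups on the core are also the same in all three compounds, so their contribution remains unknown.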